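The source may hold more compounds than are shown below. What is called first, only, known or untested is meant among the compounds shown, and "the series" means these compounds.

Of the compounds shown here, three with the same core have been tested in an ADME assay on WI-38 cells (Homo sapiens) for cytotoxicity, read by MTT assay, with a stated time of 72 h; a lower number here means a stronger inhibitor, a higher number a weaker inhibitor. Compound 1 `CCNC(=O)CCc1cccc2c1B(O)OC2` carries ethyl on the amide-type nitrogen and gives > 100000 nM, which is a limit of the assay and not a number. Compound 2 `O=C(CCc1cccc2c1B(O)OC2)NCc1ccccc1` carries benzyl there and gives > 100000 nM, also a limit. Among the measured compounds shown here, compound 3 `O=C(CCc1cccc2c1B(O)OC2)Nc1ccc(I)cc1` carries 4-iodophenyl and gives 49000 nM, the only true number of the three.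

Compound 4 `O=C(CCc1cccc2c1B(O)OC2)Nc1ccc([N+](=O)[O-])cc1` differs from compound 3 in one place, with nitro in place of iodo on an aromatic carbon. Two measured steps come closest, namely an at least 2.0-fold lower number from compound 1 to compound 3 (0.30 log units; that floor lies within the scatter) and an at least 2.0-fold lower number from compound 2 to compound 3 (0.30 log units; that floor lies within the scatter). Both change the whole group on the nitrogen, and neither exchanges the iodo for anything else, so they give no direct size for this change. Compound 4 keeps the aromatic ring of compound 3, so a number in the same region is expected, and a limit remains possible. The expected step is modest and points towards a higher number, possibly no larger than the scatter: a 1.4-fold higher number from compound 3 to compound 4 (0.15 log units; within the scatter). For compound 4 the estimated value is 70000 nM, with an expected range from 30000 nM to 100000 nM.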

Compound 4, half-maximal inhibitory concentration: > 100000 nM
Compound 4: a limit, no number; the forecaster's own chance of this, stated with the estimate: 35%; at least 1.4-fold (0.15 log units) between middle value and limit.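

Among the compounds shown here, compound 4 is the first case here where the aromatic ring on the nitrogen stays and only the group on that ring changes, on an aromatic carbon para to a large group. Exchanging iodo for nitro at that place gives an at least 2.0-fold higher number from compound 3 to compound 4 (0.30 log units; that floor lies within the scatter), so an aromatic ring on the nitrogen does not by itself bring a true number in this assay, and of the two compounds with that ring only the iodo one reads as a number. The real size of the step stays unknown, and only its floor can be read, since compound 4 gives a limit and not a number, and the assay stops at one ceiling for most of the series: the limit of > 100000 nM in this assay, at which 3 of the 4 values shown sit.

The compounds shown leave open whether another group at this position, such as an amine, a carboxylic acid or a chloro group, would give a true number or also reach the limit. With only iodo and nitro compared there, they also cannot tell whether the number for compound 3 belongs to iodo in particular.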